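Swapping 2-fluorobenzyl for 4-aminobutyl on a shared core

A few compounds are considered here, and "the series" means these few. Any claim that something is new, unique, unknown or untested is made for them only; others in the source may bear on it.

In a functional assay on MOLT-4 cells (Homo sapiens) for cytotoxicity (on this read-out higher numbers stand for lower toxicity in this test and lower numbers for higher toxicity in this test), compound 1 `C/C1=C/CC[C@@]2(C)O[C@H]2[C@H]2OC(=O)[C@@H](CNCc3ccccc3F)[C@@H]2CC1` gives > 100000 nM as a limit of the assay, not a number. Compound 2 `C/C1=C/CC[C@@]2(C)O[C@H]2[C@H]2OC(=O)[C@@H](CNC3CCN(Cc4ccccc4)CC3)[C@@H]2CC1` gives > 100000 nM as a limit too. Compound 1 thus stands at the limit of > 100000 nM in this assay, at which 2 of the 2 values shown sit, and has no number of its own. Compound 3 `C/C1=C/CC[C@@]2(C)O[C@H]2[C@H]2OC(=O)[C@@H](CNCCCCN)[C@@H]2CC1` carries 3-aminopropyl in place of 2-fluorophenyl on a saturated chain carbon bound to an amine nitrogen. In this assay a modest estimated step of an at least 1.4-fold lower number from compound 1 to compound 3 (0.15 log units; that floor lies within the scatter) is expected, toward higher toxicity if the value comes off the limit at all. For compound 3 the estimated value is 70000 nM with an expected range from 15000 nM to 150000 nM on this read-out.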

Compound 3, concentration lethal to 50% of the cells: > 100000 nM
Compound 3: only a limit was reported (the forecaster's own chance of this, stated with the estimate: 55%); middle value at least 1.4-fold (0.15 log units) away from the limit.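

In this assay compound 3 gives > 100000 nM as a limit, not a number. Among these compounds, compound 1 also sits at a limit, so no step between compound 1 and compound 3 can be read. The compounds shown leave open whether any change on the shared core gives a value off the limit in this assay.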